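Cytotoxicity limits in a coumarin-free description: the arylpiperazine series

This account rests on a few compounds, and the source may have more. Where it says the series, first, only, none or still open, it means among the compounds named here.

Measured compounds and values in a toxicity assay on HEK-293T cells (Homo sapiens) for inhibition, read by MTT assay, with a stated time of 24 h; a lower number here means that less compound is tolerated, a higher number that more compound is tolerated:
- compound 1 `O=c1oc2ccccc2c(N2CCN(c3cccc(Cl)c3Cl)CC2)c1CO`: > 50000 nM, a limit of the assay
- compound 2 `COc1cccc(N2CCN(c3c(CO)c(=O)oc4ccccc34)CC2)c1`: > 50000 nM, a limit of the assay
- compound 3 `COc1ccccc1N1CCN(c2c(CO)c(=O)oc3ccccc23)CC1`: > 50000 nM, a limit of the assay

Compound 2 stands at the limit, and the two further values shown are limits as well; no number places it above or below any other member of the set. The steps between the measured compounds, a step that the two limits leave unreadable from compound 1 to compound 2, a step that the two limits leave unreadable from compound 1 to compound 3 and a step that the two limits leave unreadable from compound 2 to compound 3, are each unreadable because of the limit of > 50000 nM in this assay, at which 3 of the 3 values shown sit.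

Compound 4 `O=c1oc2ccccc2c(N2CCN(c3ccc(Cl)c(Cl)c3)CC2)c1CO` is not yet measured in this assay. The change from compound 2 is 3,4-dichlorophenyl in place of 3-methoxyphenyl on an amine nitrogen in a ring. Going by the values given here, no measured step bears on it in a readable way: the only step that swaps a dichlorophenyl for a methoxyphenyl on the ring nitrogen is unreadable, and so are the other two. Given that every value in the set is a limit, no step beyond the scatter is expected in this assay, and the step of a number no higher from compound 2 to compound 4 (the limit leaves the size open) is an estimate of no change, with the most likely outcome again a limit. Compound 4 is therefore expected to give about 50000 nM, within a range of 25000 nM to 100000 nM.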

Compound 4, half-maximal cytotoxic concentration: > 50000 nM
Compound 4 was reported as a limit; the forecaster's own chance of this, stated with the estimate: 85%; the middle value sits exactly at the limit.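

No new step can be read for compound 4 against compound 1, compound 2 or compound 3 in this assay, because all four compounds sit at the same limit: the limit of > 50000 nM in this assay, at which 4 of the 4 values shown sit. The compounds shown leave open where the half-maximal cytotoxic concentration of each lies, and whether swapping the dichlorophenyl and methoxyphenyl groups on the ring nitrogen changes it at all.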